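Methyl for hydrogen on the sulfonamide nitrogen

This account rests on a few compounds, and the source may have more. Where it says the series, first, only, none or still open, it means among the compounds named here.

Measured so far:
compound 1, `CN(C)S(=O)(=O)Cc1noc2ccc(Cl)cc12`: 57 mg/kg
compound 2, `CNS(=O)(=O)Cc1noc2ccc(Br)cc12`: 15 mg/kg

In a functional assay on the whole organism (strain STD-dd) with Mus musculus as the target, in the maximal electroshock model, with a stated time of 2 h (a lower number here means that less compound is needed, a higher number that more compound is needed for the effect), compound 2 gives 15 mg/kg and stands lowest of the two numbers; compound 1 gives 57 mg/kg in this assay, a gap beyond the scatter, but the two differ in more than one place, so nothing can be read from that pair about any single change.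

Compound 3, `CN(C)S(=O)(=O)Cc1noc2ccc(Br)cc12`, has not yet been measured. It differs from compound 2 by methyl in place of hydrogen on a sulfonamide nitrogen. Among the compounds with values here, no measured pair isolates this change, so its size is not known from the data; the only guide is that compound 1, which carries the dimethylamino group, gives 57 mg/kg.

On that basis a moderate rise in dose is expected from a 2.5-fold higher number from compound 2 to compound 3 (0.40 log units; beyond the scatter). For compound 3 the estimate in this assay is 38 mg/kg, with a range from 16 mg/kg to 90 mg/kg.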

Compound 3, dose for half-maximal effect: 45 mg/kg
Beside the measured number, compound 3's estimate is 1.2-fold (0.07 log units) below it; low and high end bracket the measured number.
By their numbers in this assay, from the lowest: compound 2; then compounds 3 and 1 (each within the scatter of the next).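

In this assay the sulfonamide nitrogen now has a single-change reading: with bromo held constant, methyl in place of hydrogen on this nitrogen gives a 3.0-fold higher number from compound 2 to compound 3 (0.48 log units; beyond the scatter) and so counts as a modest loss, with the methylamino group needing less compound than the dimethylamino group. With the dimethylamino group held constant, bromo in place of chloro on an aromatic carbon gives a 1.3-fold lower number from compound 1 to compound 3 (0.10 log units; within the scatter) and leaves no difference that can be read at that halogen position. No measurement on hand accounts for the step at the nitrogen.

Open, on these data alone, is how this nitrogen behaves with two hydrogens, with a longer chain such as ethyl, or as part of a morpholine ring. Also open, as far as these compounds go, is whether fluoro at the halogen position, or the chloro partner of the methylamino compound, would give a readable step.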